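Ethoxy for methoxy in a small urea series

The source may hold more compounds than are shown below. What is called first, only, known or untested is meant among the compounds shown, and "the series" means these compounds.

Compounds measured so far:
Compound 1 `COc1ccc(Cl)cc1C(C)NC(=O)N(C)S(=O)(=O)c1ccc(C)cc1` gives 13800 nM in a functional assay on thoracic aorta (Rattus norvegicus, strain Wistar), with a stated time of 15 min; on this read-out higher numbers stand for an effect only at larger amounts of compound and lower numbers for an effect already at smaller amounts.
Compound 2 `CCOc1ccc(Br)cc1C(C)NC(=O)N(C)S(=O)(=O)c1ccccc1` gives 19800 nM in this assay.
Compound 3 `COc1ccc(Br)cc1C(C)NC(=O)N(C)S(=O)(=O)c1ccccc1` gives 16800 nM in this assay.

Among the measured compounds shown here, all three numbers lie close together, and none of the gaps between them exceeds the usual scatter, so no compound can be called stronger or weaker than another here.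

Compound 3 and compound 2 are a matched pair. The change between them is methyl in place of hydrogen on a saturated chain carbon bound to an oxygen on an aromatic ring, and the step it made was a 1.2-fold higher number from compound 3 to compound 2 (0.07 log units; within the scatter).

Compound 4 `CCOc1ccc(Cl)cc1C(C)NC(=O)N(C)S(=O)(=O)c1ccc(C)cc1` is not yet measured. It arises from compound 1 by methyl in place of hydrogen on a saturated chain carbon bound to an oxygen on an aromatic ring, the same change made on a different core. The difference between the core of compound 1 and the core of compound 3 is not broken down here.

For the measured compounds named here, because the only measured example of this change, a 1.2-fold higher number from compound 3 to compound 2 (0.07 log units; within the scatter), stayed within the scatter, the step from compound 1 to compound 4 is expected to be small as well, about a 1.2-fold higher number from compound 1 to compound 4 (0.08 log units; within the scatter). Compound 4 is therefore estimated at 16500 nM, with a likely range from 8000 nM to 34000 nM.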

Compound 4, half-maximal effective concentration: 12200 nM
Estimate against measurement, compound 4: 1.4-fold (0.13 log units) above; measured number inside the range.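

In this assay, going from methoxy to ethoxy gave a 1.1-fold lower number from compound 1 to compound 4 (0.05 log units; within the scatter), so on this core the change again made no difference that can be told from ordinary measurement noise. Set beside the earlier example, the two steps agree, even though one is printed as higher and the other as lower: the same change on two cores in this assay, a 1.2-fold higher number (0.07 log units; within the scatter) from compound 3 to compound 2 and a 1.1-fold lower number (0.05 log units; within the scatter) from compound 1 to compound 4, 1.3-fold (0.12 log units) apart, within the scatter of two such steps. Among the compounds shown here, this shows that on these two cores the change had a small effect both times, but it rests on only two pairs, and a step this small is a weak test of transfer, since it cannot show whether a larger effect would also carry over or whether the same would hold on a third core.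

The compounds shown stop at ethoxy, so it remains open what a longer chain such as propoxy or butoxy would do at this place. From the compounds shown here alone, it also remains open whether an amine or a carboxylic acid on that chain would move the number beyond the scatter.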